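A sulfone for morpholine on the amide carbonyl

A few compounds are considered here, and "the series" means these few. Any claim that something is new, unique, unknown or untested is made for them only; others in the source may bear on it.

Of the compounds shown here, three of a shared core have been measured in a physicochemical assay for solubility, at pH 7.4; a lower number here means a less soluble compound, a higher number a more soluble compound. Compound 1 `CC(C)(C)c1ccc2oc(N3CCCN(C(=O)CC4CCCC4)CC3)nc2c1` gives 26 ug/mL. Compound 2 `CC(C)(C)c1ccc2oc(N3CCCN(C(=O)C4CCOCC4)CC3)nc2c1` reaches only a limit of the assay, > 96 ug/mL. Compound 3 `CC(C)(C)c1ccc2oc(N3CCCN(C(=O)N4CCOCC4)CC3)nc2c1` likewise reaches only a limit, > 113 ug/mL. Compound 3 thus stands at a limit rather than at a number, and one further value shown is a limit too. The steps of an at least 3.6-fold higher number from compound 1 to compound 2 (0.56 log units; beyond the scatter) and an at least 4.3-fold higher number from compound 1 to compound 3 (0.63 log units; beyond the scatter) lie beyond the scatter, whereas a step that the two limits leave unreadable from compound 2 to compound 3. Compound 4 `CC(C)(C)c1ccc2oc(N3CCCN(C(=O)N4CCS(=O)(=O)CC4)CC3)nc2c1` differs from compound 3 by 1,1-dioxothiomorpholin-4-yl in place of morpholin-4-yl on a carbonyl carbon. Going by the values given here, no measured step covers this change directly. Compound 4 is expected to show an at least 1.1-fold lower number from compound 3 to compound 4 (0.05 log units; that floor lies within the scatter), no step beyond the scatter. Compound 4 is estimated at 100 ug/mL, within a range of 40 ug/mL to 200 ug/mL.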

Compound 4, solubility: > 103 ug/mL
Compound 4 gave a limit, no number (the forecaster's own chance of this, stated with the estimate: 50%); at least 1.0-fold (0.01 log units) between middle value and limit.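

In this assay compound 4 also reaches only a limit: the limit of > 103 ug/mL in this assay, at which 1 of the 4 values shown sits. Putting 1,1-dioxothiomorpholin-4-yl in place of cyclopentylmethyl on the carbonyl carbon gives an at least 3.9-fold higher number from compound 1 to compound 4 (0.59 log units; beyond the scatter), so a sulfur-bearing ring at this position also stands clear of compound 1, as the morpholin-4-yl and oxan-4-yl groups do. The steps among compound 2, compound 3 and compound 4 cannot be read, so these three groups cannot be ranked. Still open, as far as these compounds go, is where their true values lie, and whether an amine such as 4-methylpiperazin-1-yl on the carbonyl carbon would also reach a limit.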